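A few compounds are considered here, and "the series" means these few. Any claim that something is new, unique, unknown or untested is made for them only; others in the source may bear on it.

Measured in a functional assay on U-251 cells (Homo sapiens) for inhibition, read by sulforhodamine B assay, with a stated time of 48 h; a higher number here means that more compound is tolerated, a lower number that less compound is tolerated:
Compound 1 `Cc1ccc(C2=NN(c3ccc(S(C)(=O)=O)cc3)C(=O)CC2)cc1`: > 100000 nM, a limit of the assay
Compound 2 `Cc1cc(O)ccc1C1=NN(c2ccc(S(C)(=O)=O)cc2)C(=O)CC1`: > 100000 nM, a limit of the assay

Compound 2 has no exact reading in this assay: its > 100000 nM is a limit and not a number. For the measured compounds named here, the same holds for the only other measured compound, so the evidence so far is the limit of > 100000 nM in this assay, at which 2 of the 2 values shown sit.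

Compound 3 `CCc1ccc(C2=NN(c3ccc(S(C)(=O)=O)cc3)C(=O)CC2)cc1` keeps the shared core and carries 4-ethylphenyl in place of 4-hydroxy-2-methylphenyl on a carbon with a double bond to nitrogen.

Going by the values given here, only one measured step bears on this change. It is a step that the two limits leave unreadable from compound 1 to compound 2, which swaps 4-methylphenyl for 4-hydroxy-2-methylphenyl at the same place, and its size cannot be read. It therefore gives no measured size to carry over. With the limit of > 100000 nM in this assay, at which 2 of the 2 values shown sit, the expectation is that compound 3 stays at the same limit, with no step beyond the scatter in this assay.

The expected step is a number no higher from compound 2 to compound 3 (the limit leaves the size open). Compound 3 is estimated at about 100000 nM, with an expected range of 50000 nM to 200000 nM, and the assay will probably report only a limit again.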

Compound 3, concentration lethal to 50% of the cells: > 100000 nM
Compound 3 was reported as a limit; the forecaster's own chance of this, stated with the estimate: 85%; the middle value sits exactly at the limit.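

Compound 3 ends at a limit of the assay, as compound 1 and compound 2 do, so no step among these three compounds can be read: the limit of > 100000 nM in this assay, at which 3 of the 3 values shown sit. The compounds shown leave open how far past that limit each one lies in this assay and whether any other group at this place would give an exact reading.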